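A Second Fluoro on a Pair at the Assay Limit

A few compounds are considered here, and "the series" means these few. Any claim that something is new, unique, unknown or untested is made for them only; others in the source may bear on it.

Measured so far:
compound 1, `O/N=C(\COc1cccc2ccccc12)c1ccc(F)cc1`: > 50000 nM
compound 2, `O/N=C(\COc1cccc2ccccc12)c1ccc(Cl)cc1`: > 50000 nM

In an ADME assay on NCI-H226 cells (Homo sapiens) for cytotoxicity, read by MTT assay (a higher number here means a weaker inhibitor, a lower number a stronger inhibitor), compound 1 gives > 50000 nM, which is a limit of the assay rather than a number. Compound 2 gives > 50000 nM in this assay, again a limit. Because both values sit at the limit of > 50000 nM in this assay, at which 2 of the 2 values shown sit, the step that the two limits leave unreadable from compound 1 to compound 2 cannot be read. Compound 1 thus stands at the limit, with nothing shown beyond it.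

Compound 3, `O/N=C(\COc1cccc2ccccc12)c1ccc(F)c(F)c1`, differs from compound 1 by fluoro in place of hydrogen on an aromatic carbon. The only measured step, a step that the two limits leave unreadable from compound 1 to compound 2, concerns chloro in place of fluoro and has no readable size, so nothing shown supports a step in this assay beyond the scatter. Compound 3 is therefore expected to give 60000 nM, between 20000 nM and 200000 nM, most probably again only a limit. The step expected is a step that the limit leaves unreadable from compound 1 to compound 3.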

Compound 3, half-maximal inhibitory concentration: > 50000 nM
Compound 3 gave a limit, no number; the forecaster's own chance of this, stated with the estimate: 75%; the middle value lies beyond the limit too.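

Compound 3 also gives only a limit, not a number, so the step from compound 1 to compound 3 cannot be read: the limit of > 50000 nM in this assay, at which 3 of the 3 values shown sit.

The compounds shown leave open whether compound 1, compound 2 and compound 3 differ at all in this assay, and whether any change to the shared core would give a number rather than a limit.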